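The compounds below may be only part of what the source reports. "The series", "measured", "known", "first", "only" and "open" are said of these compounds alone.

Of the compounds shown here, three sharing one core have been tested in a functional assay on the whole organism for activation, with Mus musculus as the target; on this read-out lower numbers stand for an effect already at smaller amounts and higher numbers for an effect only at larger amounts of compound. Compound 1 `Cc1nc(N)c2nc(O)n(Cc3ccccc3)c2n1` carries a methyl group on the core, and in this assay compound 1 gives 3 mg/kg. Compound 2 `CCCCc1nc(N)c2nc(O)n(Cc3ccccc3)c2n1` carries a butyl chain in the same position; compound 2 gives 0.3 mg/kg. Compound 3 `CCCCSc1nc(N)c2nc(O)n(Cc3ccccc3)c2n1` carries a butylsulfanyl group there, and compound 3 gives 0.3 mg/kg. Among these three numbers compound 1 stands highest, so it is the compound that needs the largest amount to act.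

The step from compound 1 to compound 4 `CCCCCOc1nc(N)c2nc(O)n(Cc3ccccc3)c2n1` changes one place on the core: pentyloxy in place of methyl on an aromatic carbon. Among the measured compounds shown here, two measured steps bear on this. Lengthening the chain gave a 10-fold lower number from compound 1 to compound 2 (1.00 log units; beyond the scatter), and exchanging methyl for butylsulfanyl gave a 10-fold lower number from compound 1 to compound 3 (1.00 log units; beyond the scatter); exchanging butyl for butylsulfanyl gave no change at the digits printed from compound 2 to compound 3 (within the scatter). A longer chain, with or without a heteroatom joining it to the core, has so far lowered the number by the same amount. Pentyloxy is another chain of that kind, so the expected step is a 10-fold lower number from compound 1 to compound 4 (1.00 log units; beyond the scatter). Compound 4 is therefore estimated at 0.3 mg/kg, with a range from 0.1 mg/kg to 1 mg/kg.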

Compound 4, minimum effective dose: 0.3 mg/kg
Estimate against measurement, compound 4: no gap at the digits printed, within the range that was stated.
By their numbers in this assay, from the lowest: compounds 2, 3 and 4 (each within the scatter of the next); then compound 1.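

In this assay, pentyloxy on this aromatic carbon between two ring nitrogen atoms gives a 10-fold lower number from compound 1 to compound 4 (1.00 log units; beyond the scatter), which extends the earlier result to a chain joined to the core through oxygen. Set against the other two chains, the same group gives no change at the digits printed from compound 3 to compound 4 (within the scatter) and no change at the digits printed from compound 2 to compound 4 (within the scatter), so butyl, butylsulfanyl and pentyloxy cannot be told apart on this read-out, even though they differ in chain name and in the atom joining the chain to the core. No accompanying measurement explains why these three groups match.

Going by these compounds, it remains open whether this shared level would hold for a shorter ethoxy group or a longer octyloxy chain. The compounds shown also leave open what an amine joined at this carbon, or a carboxylic acid at the chain end, would do.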